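Mouse microsome stability: aryl exchange on the piperazine nitrogen

The source may report more compounds than this note shows. Statements on the series, on what has been measured and on what is new or still open speak of the compounds shown alone.

Compound 1 `Cc1cc(C)cc(N2CCN(C(=O)c3oc(C)nc3-c3ccccc3)CC2)c1` gives 12% in an ADME assay on microsomes from liver (Mus musculus) for metabolic stability, read by LC-MS, with a stated time of 1 h, tested at 5 uM; a higher number here means that more of the compound is left, a lower number that less of the compound is left. For the measured compounds named here, compound 2 `COc1cc(OC)cc(N2CCN(C(=O)c3oc(C)nc3-c3ccccc3)CC2)c1` gives 0.7%, and the change a number 11.3 percentage points lower from compound 1 to compound 2 (beyond the scatter) marks the only measured step in the pair. Going by the values given here, compound 2 therefore stands lowest of the two numbers known so far, with compound 1 as its nearest neighbour and higher by a margin beyond the scatter.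

Compound 3 `Cc1nc(-c2ccccc2)c(C(=O)N2CCN(c3cc(Cl)cc(Cl)c3)CC2)o1` differs from compound 2 in one place: 3,5-dichlorophenyl in place of 3,5-dimethoxyphenyl on an amine nitrogen in a ring. Among the compounds with values here, no measured step carries a 3,5-dichlorophenyl, so the only step that bears on this exchange is a number 11.3 percentage points lower from compound 1 to compound 2 (beyond the scatter), and it concerns a different pair of groups. It shows that swapping the aryl group on the ring nitrogen can move this assay by a modest amount beyond the scatter. Since compound 2 sits near the bottom of the read-out, the room for movement lies mainly upward, and a modest rise toward the level of compound 1 is expected, a number 7.3 percentage points higher from compound 2 to compound 3 (within the scatter). Compound 3 is therefore estimated at 8%, with a range from 1% to 25%.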

Compound 3, percent of the compound remaining: 43.4%
Compound 3: the middle estimate sits 35.4 percentage points below what was measured; measured number above the stated range.
By their numbers in this assay, from the lowest: compound 2; then compound 1; then compound 3.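

The aryl position on the amine nitrogen in a ring can carry far larger shifts in this assay than the first pair suggested: 3,5-dichlorophenyl gives a number 42.7 percentage points higher from compound 2 to compound 3 (beyond the scatter), and against 3,5-dimethylphenyl it gives a number 31.4 percentage points higher from compound 1 to compound 3 (beyond the scatter). For the compounds shown here, both steps are large and beyond the scatter, whereas the only earlier step was modest, so the aryl group here is a strong handle on the percent of compound remaining, and compound 3 stands highest of the three. What sets 3,5-dichlorophenyl apart from the other two aryl groups cannot be said from these numbers, as no supporting measurement bears on the result.

The compounds shown cover only three aryl groups, all with two identical groups on the phenyl ring, so it remains open whether a single chlorine, two fluorines, two trifluoromethyl groups or a pyridine ring in place of the phenyl would hold or extend this level. Going by these compounds, the rest of the core stays the same throughout, so it is also open whether the 3,5-dichlorophenyl result carries over when the methyl or the phenyl on the core is exchanged, for example for an ethyl or a cyclopropyl.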